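Diisopropylamino in place of isobutylamino: compound 3 to compound 4

This account rests on a few compounds, and the source may have more. Where it says the series, first, only, none or still open, it means among the compounds named here.

In a functional assay on MCF7 cells (Homo sapiens) for antiproliferative activity (on this read-out higher numbers stand for weaker inhibition and lower numbers for stronger inhibition), compound 1 `CCN(CC)CCCOc1ccc2cc(NC(=O)c3ccc(O)c(CC=C(C)C)c3)c(=O)oc2c1C` gives 6390 nM, compound 2 `CCCNCCCOc1ccc2cc(NC(=O)c3ccc(O)c(CC=C(C)C)c3)c(=O)oc2c1C` gives 980 nM and compound 3 `CC(C)=CCc1cc(C(=O)Nc2cc3ccc(OCCCNCC(C)C)c(C)c3oc2=O)ccc1O` gives 1320 nM. Compound 3 therefore sits level with compound 2, since a 1.3-fold higher number from compound 2 to compound 3 (0.13 log units; within the scatter) shows that propylamino and isobutylamino are not separated here. Compound 3 stands clearly lower than compound 1, with a 4.8-fold lower number from compound 1 to compound 3 (0.68 log units; beyond the scatter). The next structure is compound 4 `CC(C)=CCc1cc(C(=O)Nc2cc3ccc(OCCCN(C(C)C)C(C)C)c(C)c3oc2=O)ccc1O`, and the change is diisopropylamino in place of isobutylamino on a saturated chain carbon, three bonds along the chain from an oxygen on an aromatic ring. Among the measured compounds shown here, no diisopropylamino compound has been measured yet, so the closest guide is the diethylamino group of compound 1. For the measured compounds named here, two steps bear on the change: a 6.5-fold lower number from compound 1 to compound 2 (0.81 log units; beyond the scatter) and a 4.8-fold lower number from compound 1 to compound 3 (0.68 log units; beyond the scatter). Both are modest, and read in reverse they point towards a higher number for compound 4. The expected outcome is a 3.8-fold higher number from compound 3 to compound 4 (0.58 log units; beyond the scatter), a step beyond the scatter and similar in size to those two. The estimated value for compound 4 is 5000 nM, with an expected range of 2000 nM to 12000 nM.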

Compound 4, half-maximal inhibitory concentration: 1310 nM
Compound 4: middle estimate off by 3.8-fold (0.58 log units), on the high side; measured number outside the range, below it.
By their numbers in this assay, from the lowest: compounds 2, 4 and 3 (each within the scatter of the next); then compound 1.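

In this assay, diisopropylamino on a saturated chain carbon, three bonds along the chain from an oxygen on an aromatic ring, is not separated from isobutylamino (a 1.0-fold lower number from compound 3 to compound 4 (0.00 log units; within the scatter)) or from propylamino (a 1.3-fold higher number from compound 2 to compound 4 (0.13 log units; within the scatter)), although the hydrogen-bond donor counted on isobutylamino is gone. The same group stands clearly apart from diethylamino (a 4.9-fold lower number from compound 1 to compound 4 (0.69 log units; beyond the scatter)), so the higher number of compound 1 does not extend to this other dialkylamino group, and compound 1 alone stands apart among the four. Nothing on hand explains why diethylamino and diisopropylamino part here.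

Open, as far as these compounds go, is how a primary amine, dimethylamino or a ring amine such as piperidine or morpholine would fall at this place. Also open, from the compounds shown here alone, is whether the level seen for compounds 2, 3 and 4 holds on a shorter or longer chain.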